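Compound 1 to compound 4: a tetrazole exchange

This account rests on a few compounds, and the source may have more. Where it says the series, first, only, none or still open, it means among the compounds named here.

In an ADME assay on S9 fraction from liver (Rattus norvegicus) for metabolic stability, read by LC-MS, using NADPH, with a stated time of 30 min (on this read-out higher numbers stand for a more stable compound and lower numbers for a less stable compound), compound 1 (`CCCCCCCCc1ccc(OCC(=O)Cn2ncnn2)cc1`) gives < 5% as a limit of the assay and not a number. Compound 2 (`CCCCCCCCc1ccc(OCC(=O)Cn2nnc(-c3ccccc3Cl)n2)cc1`) gives 28% and compound 3 (`CCCCCCCCc1ccc(OCC(=O)Cn2nnc(-c3ccccn3)n2)cc1`) gives 30% with no difference beyond the scatter (a number 2 percentage points higher from compound 2 to compound 3 (within the scatter)).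

Compound 4 (`CCCCCCCCc1ccc(OCC(=O)Cn2nnnc2SC)cc1`) comes from a different exchange (5-(methylsulfanyl)-1H-tetrazol-1-yl in place of 2H-tetrazol-2-yl on a saturated chain carbon bound to a carbonyl carbon): 5-(methylsulfanyl)-1H-tetrazol-1-yl in place of 2H-tetrazol-2-yl on a saturated chain carbon bound to a carbonyl carbon. The nearest guides are two steps beyond the scatter, each on an aromatic carbon: 2-chlorophenyl in place of hydrogen (a number at least 23 percentage points higher from compound 1 to compound 2 (beyond the scatter)) and pyridin-2-yl in place of hydrogen (a number at least 25 percentage points higher from compound 1 to compound 3 (beyond the scatter)). They bear on compound 4 only in part, as the entering group is neither of these and is a 1H-tetrazol-1-yl.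

A modest upward step is expected (a number at least 15 percentage points higher from compound 1 to compound 4 (beyond the scatter)), probably no larger than those two. For compound 4 the estimated value is 20% (expected range 6% to 38%).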

Compound 4, percent of the compound remaining: 21%
Beside the measured number, compound 4's estimate is 1 percentage points below it; the measured number falls inside the stated range.
By their numbers in this assay, from the lowest: compounds 4, 2 and 3 (each within the scatter of the next). At a limit, below all of these: compound 1.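

In this assay, the exchange of 2H-tetrazol-2-yl for 5-(methylsulfanyl)-1H-tetrazol-1-yl on the saturated chain carbon bound to the carbonyl carbon gives a number at least 16 percentage points higher from compound 1 to compound 4 (beyond the scatter). The earlier upward steps came only with 2-chlorophenyl or pyridin-2-yl, so a step beyond the scatter at this tetrazole is not tied to an added aromatic ring, and methylsulfanyl with a changed ring attachment also gives one. Its true size stays unknown, as compound 1 sits at a limit: the limit of < 5% in this assay, at which 1 of the 4 values shown sits.

Going by these compounds, the ring attachment and the methylsulfanyl group change together here, so the share of each in the step stays open. Also open, on these data alone, is how this read-out would respond to an amine, a carboxylic acid or a methoxy group on the 1H-tetrazol-1-yl ring.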